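A few compounds are considered here, and "the series" means these few. Any claim that something is new, unique, unknown or untested is made for them only; others in the source may bear on it.

Measured in an in vitro ADME assay on microsomes (Homo sapiens) for metabolic stability; a higher number here means that the compound lasts longer, a lower number that the compound disappears faster:
- Compound 1 `O=C(Nc1ccccc1)Nc1ccc(-c2nc(N3CC4CCC(C3)O4)c3cnn(C4CCC5(CC4)OCCO5)c3n2)cc1`: 0.217 h
- Compound 2 `CNC(=O)Nc1ccc(-c2nc(N3CC4CCC(C3)O4)c3cnn([C@H]4CC[C@@H](O)CC4)c3n2)cc1`: > 0.5 h (a limit)

Compound 2 stands at a limit of this assay, not at a number: > 0.5 h. Compound 3 `CNC(=O)Nc1ccc(-c2nc(N3CC4CCC(C3)O4)c3cnn(C4CCC(OC)(OC)CC4)c3n2)cc1` differs from compound 2 only in the group on an aromatic nitrogen: a group of 10 heavy atoms (8 carbon, 2 oxygen; one six-membered non-aromatic ring of carbon only) in place of a group of 7 heavy atoms (6 carbon, 1 oxygen; one six-membered non-aromatic ring of carbon only), on an aromatic nitrogen. Among the compounds with values here, no measured step shows what such a change does in this assay. Within the data shown here, the only exact number available is that of compound 1, 0.217 h. A modest fall in half-life is expected, an estimated step of an at least 1.6-fold lower number from compound 2 to compound 3 (0.22 log units; that floor lies within the scatter). Compound 3 is estimated at 0.3 h, with an expected range of 0.13 h to 0.6 h.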

Compound 3, half-life: 0.5 h
Beside the measured number, compound 3's estimate is 1.7-fold (0.22 log units) below it; low and high end bracket the measured number.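

Replacing 4-hydroxycyclohexyl with the group of 10 heavy atoms on the aromatic nitrogen gives, in this assay, a number no higher from compound 2 to compound 3 (the limit leaves the size open). The size of this step stays open, as compound 2 stands at a limit of the assay: the limit of > 0.5 h in this assay, at which 1 of the 3 values shown sits.

With the core shared by compound 2 and compound 3, a group with 0 hydrogen-bond donors at this position now has an exact reading. Still open, as far as these compounds go, is how long compound 2 actually lasts, and how the half-life would respond to an amine, a carboxylic acid or an open carbon chain on this nitrogen.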